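This account rests on a few compounds, and the source may have more. Where it says the series, first, only, none or still open, it means among the compounds named here.

Of the compounds shown here, two built on one shared core have been tested in an assay on CHO cells for displacement of a labelled ligand from adenosine receptor A1 (Homo sapiens), read by scintillation counting, with a stated time of 90 min, in the presence of a further agent that is not named here; on this read-out higher numbers stand for weaker inhibition and lower numbers for stronger inhibition. Compound 1 `CCCn1c(=O)[nH]c2nc(-c3ccc(S(=O)(=O)N4CCN(Cc5cccc(Br)c5)CC4)cc3)[nH]c2c1=O` gives 928 nM. Compound 2 `CCCn1c(=O)[nH]c2nc(-c3ccc(S(=O)(=O)N4CCN(Cc5ccc(Br)c(F)c5)CC4)cc3)[nH]c2c1=O` gives 326 nM. Within the data shown here, the only change from compound 1 to compound 2 is 4-bromo-3-fluorophenyl in place of 3-bromophenyl on a saturated chain carbon bound to an amine nitrogen in a ring, and this change moves the number a 2.8-fold lower number from compound 1 to compound 2 (0.45 log units; beyond the scatter). Of the two numbers, compound 2 therefore stands as the lower one, and by a margin beyond the usual scatter.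

The next compound, compound 3 `CCCn1c(=O)[nH]c2nc(-c3ccc(S(=O)(=O)N4CCN(c5ccccc5F)CC4)cc3)[nH]c2c1=O`, differs from compound 2 in one place: 2-fluorophenyl in place of 4-bromo-3-fluorobenzyl on an amine nitrogen in a ring. This is a different kind of change from the one already measured, which only reshuffled halogens on the benzyl ring, so that step from compound 1 to compound 2 gives no firm guidance here. With a smaller group now sitting directly on the ring nitrogen, the outcome is open; a shift in either direction is possible, and weakening seems somewhat more likely than strengthening. Compound 3 is therefore expected to show a 2.5-fold higher number from compound 2 to compound 3 (0.39 log units; beyond the scatter), with an estimated 800 nM and a wide range from 200 nM to 3000 nM.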

Compound 3, inhibition constant: > 1000 nM
Compound 3: a limit, no number; the forecaster's own chance of this, stated with the estimate: 5%; middle value at least 1.2-fold (0.09 log units) from the limit.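

In this assay the reading for compound 3 is a limit of the assay and not a number, so each step to it gives only a floor: the limit of > 1000 nM in this assay, at which 1 of the 3 values shown sits.

Even so, this position tolerates more than a reshuffling of halogens can reveal: with 2-fluorophenyl in place of 4-bromo-3-fluorobenzyl on the amine nitrogen in the ring, the result is an at least 3.0-fold higher number from compound 2 to compound 3 (0.48 log units; beyond the scatter), so the best benzyl group shown here cannot be swapped for this directly attached phenyl ring without losing inhibition. Against the 3-bromobenzyl group the picture is less clear, with an at least 1.0-fold higher number from compound 1 to compound 3 (0.03 log units; that floor lies within the scatter), a floor that supports no claim of a difference, though the true gap may be larger.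

The swap removes the bromine and the chain carbon of the benzyl group together, and it also moves the fluorine, so the compounds shown cannot say which of these changes matters. A 2-fluorobenzyl group would separate them, while an unsubstituted phenyl or a longer chain such as 2-phenylethyl on the same nitrogen would show how the distance from the ring nitrogen to the aromatic ring plays out.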